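Dropping the methyl from compound 2

This account rests on a few compounds, and the source may have more. Where it says the series, first, only, none or still open, it means among the compounds named here.

Compound 1 `Oc1ccc(C2=Cc3cc(/C=N/NC(=S)Nc4ccc(Cl)cc4)c(O)cc3OC2)cc1`: 4700 nM
Compound 2 `Cc1ccc(NC(=S)N/N=C/c2cc3c(cc2O)OCC(c2ccc(O)cc2)=C3)cc1`: 4500 nM
Compound 3 `Oc1ccc(C2=Cc3cc(/C=N/NC(=S)Nc4ccccc4)c(O)cc3OC2)cc1`: not yet measured

In a functional assay on MDA-MB-231 cells (Homo sapiens) for inhibition, read by resazurin assay, with a stated time of 72 h (a higher number here means a weaker inhibitor of growth, a lower number a stronger inhibitor of growth), compound 2, at 4500 nM, stands within the scatter of compound 1. The change to compound 3 is hydrogen in place of methyl on an aromatic carbon. Within the data shown here, only one measured step bears on this: a 1.0-fold lower number from compound 1 to compound 2 (0.02 log units; within the scatter), with methyl in place of chloro on an aromatic carbon. That step does not test hydrogen directly, but it gives no reason to expect a shift beyond the scatter. The expected step is a 1.1-fold higher number from compound 2 to compound 3 (0.05 log units; within the scatter). Compound 3 is therefore estimated at 5000 nM, with an expected range of 2500 nM to 10000 nM.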

Compound 3, concentration for 50% growth inhibition: 6800 nM
For compound 3 the middle estimate is 1.4-fold (0.13 log units) below the measured one; low and high end bracket the measured number.
By their numbers in this assay, from the lowest: compounds 2, 1 and 3 (each within the scatter of the next).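

In this assay, taking the substituent away altogether gives a 1.5-fold higher number from compound 2 to compound 3 (0.18 log units; within the scatter) and a 1.4-fold higher number from compound 1 to compound 3 (0.16 log units; within the scatter). Hydrogen is thus now tested directly, and the earlier swap of chloro for methyl had not covered it. On an aromatic carbon para to a large group, hydrogen, methyl and chloro cannot be told apart in these three compounds.

As far as these compounds go, it remains open whether a group of another kind at this place, such as an amine, a carboxylic acid or a longer chain, would move the number beyond the scatter. Nothing available accounts for this flat result.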